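Amide-side variation on a chloropurine series: compound 3 to compound 4

A few compounds are considered here, and "the series" means these few. Any claim that something is new, unique, unknown or untested is made for them only; others in the source may bear on it.

Measured so far in a functional assay on the whole organism with Mus musculus as the target, with a stated time of 90 min, at a dose of 25 umol/kg by the oral route; on this read-out higher numbers stand for a stronger effect at the one dose given and lower numbers for a weaker effect:
compound 1 `CCOC(=O)CN(c1nc(Cl)nc2c1ncn2C1CCCCO1)C1CC1` gives 13%
compound 2 `O=C(O)CN(c1nc(Cl)nc2c1ncn2C1CCCCO1)C1CC1` gives 8.22%
compound 3 `O=C(CN(c1nc(Cl)nc2c1ncn2C1CCCCO1)C1CC1)N[C@@H](CC(=O)OCc1ccccc1)C(=O)OCc1ccccc1` gives 25.1%

Compound 3 stands highest of the three numbers; its gap to compound 1 and its gap to compound 2 both lie beyond the usual scatter, so compound 3 is the most active of the measured set. For the measured compounds named here, the only single-point step measured so far is a number 4.8 percentage points lower from compound 1 to compound 2 (within the scatter), which concerns the ester-to-acid change and not the amide side of the molecule.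

Compound 4 `C[C@@H](O)[C@H](NC(=O)CN(c1nc(Cl)nc2c1ncn2C1CCCCO1)C1CC1)C(=O)OCc1ccccc1` carries the change (1-hydroxyethyl in place of (benzyloxycarbonyl)methyl on a saturated chain carbon bound to an amide-type nitrogen and a carbonyl carbon). Going by the values given here, no measured step touches this position, so nothing in the set tells whether the amide substituent matters; the one measured step is small and elsewhere. Compound 4 is therefore expected to sit near compound 3, with a step of a number 6.1 percentage points lower from compound 3 to compound 4 (within the scatter) that may fall within the scatter, and its estimate in this assay is 19% with a range from 8% to 32%.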

Compound 4, a percentage reported as activity, at one dose (the size of the read-out at that dose, not a potency): 23.4%
Estimate against measurement, compound 4: 4.4 percentage points below; the measured number falls inside the stated range.
By their numbers in this assay, from the lowest: compounds 2 and 1 (each within the scatter of the next); then compounds 4 and 3 (each within the scatter of the next).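

At the saturated chain carbon bound to an amide-type nitrogen and a carbonyl carbon, 1-hydroxyethyl in place of (benzyloxycarbonyl)methyl gives, in this assay, a number 1.7 percentage points lower from compound 3 to compound 4 (within the scatter). This change takes away 11 heavy atoms with one six-membered aromatic ring of carbon only and brings in 3 heavy atoms with no ring, so at this one dose neither the ring nor the larger group is shown to be needed at this position. No measurement available here bears on why the read-out holds across this change.

Still open, going by these compounds, is how an amine, a carboxylic acid or a longer alkyl chain at this carbon would read in this assay. The single dose also gives no potency, so it leaves open whether compound 3 and compound 4 would separate across a range of doses.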